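From trifluoromethyl to methyl on a shared core

A few compounds are considered here, and "the series" means these few. Any claim that something is new, unique, unknown or untested is made for them only; others in the source may bear on it.

Measured so far in a functional assay on PC-3 cells (Homo sapiens) for cytotoxicity, read by MTT assay, with a stated time of 72 h; a lower number here means a stronger inhibitor, a higher number a weaker inhibitor:
Compound 1 `CC1=C(/C=C/C(=O)/C=C/c2cccc(C(F)(F)F)c2)C(C)(C)CCC1O` gives 3500 nM
Compound 2 `CC1=C(/C=C/C(=O)/C=C/c2ccc(F)c(C(F)(F)F)c2)C(C)(C)CCC1O` gives 7300 nM
Compound 3 `CC1=C(/C=C/C(=O)/C=C/c2cccc(C(F)(F)F)c2F)C(C)(C)CCC1O` gives 2100 nM

Within the data shown here, compound 1 stands with a 1.7-fold lower number from compound 1 to compound 3 (0.22 log units; within the scatter) on one side and a 2.1-fold higher number from compound 1 to compound 2 (0.32 log units; beyond the scatter) on the other, so only one of its two neighbours lies clearly apart. The next compound to be tested, compound 4 `CC1=C(/C=C/C(=O)/C=C/c2cccc(C)c2)C(C)(C)CCC1O` keeps the core of compound 1 and alters one group. The difference is methyl in place of trifluoromethyl on an aromatic carbon that is, methyl in place of trifluoromethyl on an aromatic carbon, meta to a large group.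

Among the measured compounds shown here, every measured compound carries the trifluoromethyl group, so no measured step shows this replacement directly. Both available steps are fluoro in place of hydrogen on an aromatic carbon, and they serve only as a gauge of how far one change on this aromatic ring has moved the number. Taking a 2.1-fold higher number from compound 1 to compound 2 (0.32 log units; beyond the scatter) and a 1.7-fold lower number from compound 1 to compound 3 (0.22 log units; within the scatter) as that gauge, neither sets a direction for the new change. A step of about that size at most is expected in this assay with none beyond the scatter the likeliest outcome. The expected step is a 1.1-fold higher number from compound 1 to compound 4 (0.06 log units; within the scatter) in either case a rough estimate. Compound 4 is estimated at 4000 nM with the expected value lying between 1600 nM and 10000 nM on present evidence.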

Compound 4, half-maximal inhibitory concentration: 6200 nM
Compound 4: middle estimate off by 1.6-fold (0.19 log units), on the low side; the range from low to high includes it.
By their numbers in this assay, from the lowest: compounds 3, 1, 4 and 2 (each within the scatter of the next, the first and the last beyond it).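

In this assay, among these compounds, the replacement of trifluoromethyl itself can now be read directly for the first time: methyl in place of trifluoromethyl on an aromatic carbon, meta to a large group, gives a 1.8-fold higher number from compound 1 to compound 4 (0.25 log units; within the scatter). The earlier compounds shown here all kept the trifluoromethyl group and could only show what a fluoro added to the same ring does, whereas this step shows that the trifluoromethyl group can give way to methyl, with three fewer heavy atoms, without a change beyond the scatter, so compound 1 and compound 4 cannot be put in order. Nothing measured for these compounds accounts for the size or direction of this step.

The compounds shown leave open whether other groups at this place, such as a methoxy group, a chlorine atom, an amine or a carboxylic acid, would also stay within the scatter of compound 1 or would move the number clearly. They also leave open whether the two fluoro steps seen with trifluoromethyl on the ring would recur with methyl in its stead, or whether a longer chain such as ethyl would be tolerated.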